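Cyclohexyl on the amine nitrogen: from compound 2 to compound 3

The compounds below may be only part of what the source reports. "The series", "measured", "known", "first", "only" and "open" are said of these compounds alone.

In a functional assay on HT-29 cells (Homo sapiens) for inhibition, read by sulforhodamine B assay, with a stated time of 72 h (a higher number here means a weaker inhibitor, a lower number a stronger inhibitor), compound 1 `CC(C)CNC(=C\C(=O)/C=C/c1ccc(O)cc1)/C=C/c1ccc(O)cc1` gives 22500 nM, and compound 2 `CCC(C)NC(=C\C(=O)/C=C/c1ccc(O)cc1)/C=C/c1ccc(O)cc1` gives 15600 nM. These two values lie within the scatter of each other, so compound 2 cannot be separated from compound 1 on these numbers. Compound 3 `O=C(/C=C(/C=C/c1ccc(O)cc1)NC1CCCCC1)/C=C/c1ccc(O)cc1` carries cyclohexyl in place of sec-butyl on an amine nitrogen. Among the compounds with values here, only one measured step bears on this change: a 1.4-fold lower number from compound 1 to compound 2 (0.16 log units; within the scatter), which also exchanges the group on the amine nitrogen. Within the data shown here, that step is small, but no measured compound has a ring at this place, so the evidence is limited. No step beyond the scatter is expected in this assay, and neither direction is favoured. The estimated change is a 1.0-fold lower number from compound 2 to compound 3 (0.02 log units; within the scatter). The estimate for compound 3 is 15000 nM, with an expected range of 6000 nM to 35000 nM.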

Compound 3, half-maximal inhibitory concentration: 5900 nM
Beside the measured number, compound 3's estimate is 2.5-fold (0.41 log units) above it, outside the stated range (below it).
By their numbers in this assay, from the lowest: compound 3; then compounds 2 and 1 (each within the scatter of the next).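

In this assay the group on the amine nitrogen now matters beyond the scatter: cyclohexyl in place of sec-butyl gives a 2.6-fold lower number from compound 2 to compound 3 (0.42 log units; beyond the scatter) and cyclohexyl in place of isobutyl gives a 3.8-fold lower number from compound 1 to compound 3 (0.58 log units; beyond the scatter) in the same direction. The two open-chain groups in compound 1 and compound 2 could not be separated, so this position looked indifferent until the six-membered ring of carbon appeared, and compound 3 is now the most potent of the three, though both steps are modest. No available evidence explains the gain at this position.

The compounds shown leave open whether the lower number goes with the ring itself or simply with the larger carbon count of the group. A straight hexyl chain, a cyclopentyl ring or a phenyl ring on the same nitrogen would bear on that question.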